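Swapping Chloro for Methoxy on the Second Aryl Ring

The source may report more compounds than this note shows. Statements on the series, on what has been measured and on what is new or still open speak of the compounds shown alone.

Measured so far:
- Compound 1 `COc1ccccc1/C=c1\c(=O)[nH]/c(=C/c2cccc(Cl)c2Cl)c(=O)n1C`: 200 nM
- Compound 2 `C=CCn1c(=O)/c(=C\c2ccc(Cl)c(Cl)c2)[nH]c(=O)/c1=C\c1ccccc1`: "not active" (no number reported)
- Compound 3 `COc1ccccc1/C=c1\c(=O)[nH]/c(=C/c2ccccc2Cl)c(=O)n1C`: 200 nM

In a functional assay on HL-60 cells (Homo sapiens) for cytotoxicity, read by CCK-8 assay, with a stated time of 72 h (on this read-out higher numbers stand for weaker inhibition and lower numbers for stronger inhibition), compound 3 gives 200 nM, and compound 1 gives 200 nM, so the two stand level. Among the compounds with values here, the single measured step, no change at the digits printed from compound 1 to compound 3 (within the scatter), lies within the scatter. Compound 2, in this assay, is reported as "not active" (no number reported) without a number.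

Compound 4 `COc1ccccc1/C=c1/[nH]c(=O)/c(=C\c2ccccc2OC)n(C)c1=O` differs from compound 3 by methoxy in place of chloro on an aromatic carbon; cut one bond further out, the change reads 2-chlorophenyl to 2-methoxyphenyl. Within the data shown here, the only relevant step, no change at the digits printed from compound 1 to compound 3 (within the scatter), altered that same chloro without effect, so no step beyond the scatter is expected: a 1.1-fold higher number from compound 3 to compound 4 (0.04 log units; within the scatter). Compound 4 is therefore estimated at 220 nM, between 80 nM and 600 nM.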

Compound 4, half-maximal inhibitory concentration: 16200 nM
Estimate against measurement, compound 4: 74-fold (1.87 log units) below, and the stated range ends below it.
By their numbers in this assay, from the lowest: compounds 1 and 3 (each within the scatter of the next); then compound 4.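

Not every change on this ring is tolerated. Losing one chloro left the number flat, but methoxy in place of the remaining chloro brings a large loss of cytotoxic strength (an 81-fold higher number from compound 3 to compound 4 (1.91 log units; beyond the scatter)). Measured against the 2,3-dichlorophenyl ring of compound 1, the 2-methoxyphenyl ring shows the same large loss (an 81-fold higher number from compound 1 to compound 4 (1.91 log units; beyond the scatter)).

As far as these compounds go, whether a fluoro or a methyl group on this carbon would keep the strength of compound 3 stays open. Nothing available explains why methoxy does so much worse here.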